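Ether-chain homologation and cytotoxicity in the series

This account rests on a few compounds, and the source may have more. Where it says the series, first, only, none or still open, it means among the compounds named here.

In an ADME assay on HFFF cells (Homo sapiens) for cytotoxicity, read by luminescence (on this read-out higher numbers stand for lower toxicity in this test and lower numbers for higher toxicity in this test), compound 2 `CCCOCCCCCCCCCc1cc2cn([C@@H]3CC[C@H](CO)O3)c(=O)nc2o1` stands at > 100000 nM, a limit of the test and not a number. Compound 1 `CCOCCCCCCCCCc1cc2cn([C@@H]3CC[C@H](CO)O3)c(=O)nc2o1` likewise reaches only > 100000 nM, again a limit. Among the compounds with values here, the one step between measured compounds, a step that the two limits leave unreadable from compound 1 to compound 2, cannot be sized. Compound 3 `CCCCOCCCCCCCCCc1cc2cn([C@@H]3CC[C@H](CO)O3)c(=O)nc2o1` differs from compound 2 by methyl in place of hydrogen on a saturated chain carbon, three bonds along the chain from an oxygen on a saturated carbon. The step from compound 1 to compound 2 is the only one that bears on this change, and it is unreadable; what remains is the limit of > 100000 nM in this assay, at which 2 of the 2 values shown sit. For compound 3 a step that the limit leaves unreadable from compound 2 to compound 3 is expected, most likely another limit, with an estimate of 150000 nM between 60000 nM and 400000 nM.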

Compound 3, half-maximal cytotoxic concentration: > 100000 nM
Compound 3: no number, only a limit (the forecaster's own chance of this, stated with the estimate: 85%); the middle value is on the limit's open side.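

Within the data shown here, no step among compound 1, compound 2 and compound 3 can be read in this assay: all three values are limits. Still open, as far as these compounds go, is whether any ether chain length gives a measurable cytotoxic concentration in this assay.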